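Notes on the amide-to-carbamate change at the piperidine nitrogen

A few compounds are considered here, and "the series" means these few. Any claim that something is new, unique, unknown or untested is made for them only; others in the source may bear on it.

Measured compounds:
compound 1 `O=C(c1ccc(Cl)cc1)N1CCC(NS(=O)(=O)c2cc(S(=O)(=O)c3ccccc3)ccc2C(F)(F)F)CC1` gives 1800 nM in an assay on U2OS cells for inhibition of secreted frizzled-related protein 1 (Homo sapiens), read by a luciferase reporter, with a stated time of 18 h; on this read-out lower numbers stand for an effect already at smaller amounts and higher numbers for an effect only at larger amounts of compound;
compound 2 `O=C(O)c1cccc(S(=O)(=O)N2CCC(NS(=O)(=O)c3cc(S(=O)(=O)c4ccccc4)ccc3C(F)(F)F)CC2)c1` gives 190 nM;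
compound 3 `O=C(O)c1ccc(S(=O)(=O)N2CCC(NS(=O)(=O)c3cc(S(=O)(=O)c4ccccc4)ccc3C(F)(F)F)CC2)cc1` gives 110 nM.

Compound 1 stands highest of the three numbers; the step of a 9.5-fold lower number from compound 1 to compound 2 (0.98 log units; beyond the scatter) and the step of a 16-fold lower number from compound 1 to compound 3 (1.21 log units; beyond the scatter) both lower the number clearly, while a 1.7-fold lower number from compound 2 to compound 3 (0.24 log units; within the scatter) lies within the scatter.

Compound 4 `CC(C)(C)OC(=O)N1CCC[C@H]1C(=O)N1CCC(NS(=O)(=O)c2cc(S(=O)(=O)c3ccccc3)ccc2C(F)(F)F)CC1` is not yet measured. It differs from compound 1 by 1-(tert-butoxycarbonyl)pyrrolidin-2-yl in place of 4-chlorophenyl on a carbonyl carbon. Both measured steps replace the carbonyl and its aryl group together with a carboxyphenyl sulfonyl, so neither bears directly on keeping the carbonyl while exchanging the aryl for a saturated carbamate-bearing ring. Among the measured compounds shown here, no step shows the effect of that change. A step of no size beyond the scatter is therefore expected, a 1.1-fold higher number from compound 1 to compound 4 (0.05 log units; within the scatter). Compound 4 is expected to give about 2000 nM, between 600 nM and 6500 nM.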

Compound 4, half-maximal effective concentration: 60 nM
Beside the measured number, compound 4's estimate is 33-fold (1.52 log units) above it; the measured number lies below the stated range.
By their numbers in this assay, from the lowest: compounds 4, 3 and 2 (each within the scatter of the next, the first and the last beyond it); then compound 1.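

In this assay, the carbonyl on the ring nitrogen stays in place and the exchange of the group on it alone gives a 30-fold lower number from compound 1 to compound 4 (1.48 log units; beyond the scatter). Among the compounds shown here, the earlier steps changed the carbonyl and its aryl group together, so this is the first reading showing that this position responds strongly with the carbonyl kept. Nothing available explains the size of this step.

Open, going by these compounds, is whether the step follows the pyrrolidine ring or the tert-butoxycarbonyl group; the free pyrrolidine amine or an acetyl group on that nitrogen would separate the two. On these data alone, the mirror-image form at the defined stereocentre also remains open.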